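The compounds below may be only part of what the source reports. "The series", "measured", "known", "first", "only" and "open" are said of these compounds alone.

- Compound 1 `COc1cccc(/C=C/C(=O)Nc2cc(OC)c(OC)c(OC)c2)c1` gives 43000 nM
- Compound 2 `C=C(Br)C(=O)Nc1cccc(/C=C/C(=O)Nc2ccccc2)c1` gives 3900 nM
- Compound 3 `C=C(Br)C(=O)Nc1cccc(/C=C/C(=O)Nc2cccc3ccccc23)c1` gives 1160 nM

In a functional assay on LoVo cells (Homo sapiens) for inhibition, read by MTT assay, with a stated time of 72 h (on this read-out higher numbers stand for weaker inhibition and lower numbers for stronger inhibition), compound 2, at 3900 nM, holds the middle of these three numbers. Compound 3 lies clearly lower and compound 1 clearly higher, so compound 2 is a moderate inhibitor within this small set.

Compound 4 `C=C(Br)C(=O)Nc1cccc(/C=C/C(=O)Nc2cccc(F)c2)c1` departs from compound 2 in a single place: fluoro in place of hydrogen on an aromatic carbon. In words, this is fluoro in place of hydrogen on an aromatic carbon, which turns the phenyl into a 3-fluorophenyl. Going by the values given here, none of the measured compounds shows what this swap does, so any forecast is loose. Since only one hydrogen is replaced, no large shift is expected in this assay, and there is at most a slight lean towards a lower number. The estimated 1.3-fold lower number from compound 2 to compound 4 (0.11 log units; within the scatter) is expected to stay within the usual scatter of repeated measurements. For compound 4 the estimated value is 3000 nM, with an expected range from 1300 nM to 7000 nM.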

Compound 4, half-maximal inhibitory concentration: 1000 nM
Compound 4: the middle estimate sits 3.0-fold (0.48 log units) above what was measured; measured number outside the range, below it.
By their numbers in this assay, from the lowest: compounds 4 and 3 (each within the scatter of the next); then compound 2; then compound 1.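

In this assay, putting one fluoro on the phenyl of compound 2 goes with a 3.9-fold lower number from compound 2 to compound 4 (0.59 log units; beyond the scatter) and so the ring position named by 3-fluorophenyl is not indifferent to change. Going by these compounds alone, this pair is the first in the set that differs in one place only, and it shows that replacing a single hydrogen on an aromatic carbon can be enough to shift the number towards stronger inhibition. Nothing at hand explains why the number falls.

As far as these compounds go, whether a chloro, a methoxy or an amine at this same place would shift the number as fluoro does remains open. From the compounds shown here alone, it is also open whether fluoro on a different carbon of the ring would give a similar step, and whether one pair of compounds reflects a wider trend.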